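The source may hold more compounds than are shown below. What is called first, only, known or untested is meant among the compounds shown, and "the series" means these compounds.

Of the compounds shown here, three built on one shared core have been tested in a functional assay on MDA-MB-231 cells (Homo sapiens) for inhibition, with a stated time of 72 h; a lower number here means a stronger inhibitor, a higher number a weaker inhibitor. Compound 1, `Cc1ccc(NC(=O)Nc2nc(Nc3ccccc3)cc(Sc3c[nH]c4ccccc34)n2)cc1`, gives 13400 nM. Compound 2, `O=C(Nc1ccccc1)Nc1nc(Sc2c[nH]c3ccccc23)cc(N2CCN(Cc3ccccc3)CC2)n1`, gives 10200 nM. Compound 3, `Cc1ccc(C)c(NC(=O)Nc2nc(Sc3c[nH]c4ccccc34)cc(N3CCCCC3)n2)c1`, gives 5940 nM, the lowest of the three numbers. The gap between compound 3 and compound 2 lies within the usual scatter of repeated measurements, so these two cannot be told apart. The gap between compound 3 and compound 1 lies beyond that scatter, so compound 3 is the stronger inhibitor of that pair.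

The next compound, compound 4, is `O=C(Nc1ccccc1)Nc1nc(Sc2c[nH]c3ccccc23)cc(N2CCCCC2)n1`. It differs from compound 3 in a single place: phenyl in place of 2,5-dimethylphenyl on an amide-type nitrogen. The rest of the molecule is unchanged.

Among the compounds with values here, no measured pair in this small set isolates that change, so there is no measured step to lean on. A point of reference is compound 2, which also carries a phenyl on an amide-type nitrogen and gives 10200 nM, while compound 3 gives 5940 nM. With these two values close together, the expected step of a 1.5-fold higher number from compound 3 to compound 4 (0.18 log units; within the scatter) is small, toward a somewhat higher number, and may fall within the scatter. For compound 4 the estimated value in this assay is 9000 nM, with an expected range from 3500 nM to 22000 nM.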

Compound 4, half-maximal inhibitory concentration: 8130 nM
Compound 4: the middle estimate sits 1.1-fold (0.04 log units) above what was measured; the measured number falls inside the stated range.
By their numbers in this assay, from the lowest: compounds 3, 4, 2 and 1 (each within the scatter of the next, the first and the last beyond it).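

Within the data shown here, compound 3 and compound 4 form the first pair in this set that differs in one place only, so the methyl groups of the 2,5-dimethylphenyl can now be judged on their own. In this assay, replacing that group with a plain phenyl on the amide-type nitrogen gives a 1.4-fold higher number from compound 3 to compound 4 (0.14 log units; within the scatter) and the two compounds cannot be told apart, so at this position the methyl groups make no difference that this assay can resolve, although a small effect could still hide within the scatter. No supporting measurement bears on this result, and the data offer no explanation for it.

From the compounds shown here alone, it remains open whether a different group on that phenyl, such as a chlorine, a methoxy group or a carboxylic acid, would move the number beyond the scatter. Going by these compounds, it is also open whether the same swap would read the same way if the other substituent on the shared core were something else, such as a morpholine or a short chain ending in an amine.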